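This account rests on a few compounds, and the source may have more. Where it says the series, first, only, none or still open, it means among the compounds named here.

In a functional assay on HepG2 cells (Homo sapiens) for cytotoxicity, read by MTT assay, with a stated time of 24 h (a higher number here means a weaker inhibitor, a lower number a stronger inhibitor), compound 1 `O=C1/C(=C/c2cccnc2)CN(S(=O)(=O)c2ccc(Cl)cc2)C/C1=C\c1ccccc1F` gives 12400 nM, compound 2 `O=C1/C(=C/c2cccnc2)CN(S(=O)(=O)c2ccc(Br)cc2)C/C1=C\c1ccccc1F` gives 8700 nM and compound 3 `N#Cc1ccc(S(=O)(=O)N2C/C(=C\c3cccnc3)C(=O)/C(=C/c3ccccc3F)C2)cc1` gives 6600 nM. These numbers do not separate compound 2 from the other two: a 1.4-fold lower number from compound 1 to compound 2 (0.15 log units; within the scatter), and a 1.3-fold lower number from compound 2 to compound 3 (0.12 log units; within the scatter). Compound 4 `O=C1/C(=C/c2ccncc2)CN(S(=O)(=O)c2ccc(Br)cc2)C/C1=C\c1ccccc1F` differs from compound 2 at one place: pyridin-4-yl in place of pyridin-3-yl on a double-bonded chain carbon bound to a double-bonded ring carbon. For the measured compounds named here, no measured step covers this change. The nearest evidence is the exchange of groups on an aromatic carbon, such as a 1.9-fold lower number from compound 1 to compound 3 (0.27 log units; within the scatter), so it bears only indirectly. No step beyond the scatter is expected in this assay, and no direction is favoured. The expected step is small: a 1.0-fold lower number from compound 2 to compound 4 (0.01 log units; within the scatter). For compound 4 the estimated value is 8500 nM, with an expected range of 4500 nM to 16000 nM.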

Compound 4, half-maximal inhibitory concentration: 9300 nM
Compound 4: middle estimate off by 1.1-fold (0.04 log units), on the low side, within the range that was stated.
By their numbers in this assay, from the lowest: compounds 3, 2, 4 and 1 (each within the scatter of the next).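

For the compounds shown here, the earlier compounds varied only a group on an aromatic carbon; compound 4 gives the first reading at the double-bonded chain carbon bound to a double-bonded ring carbon. In this assay, pyridin-4-yl in place of pyridin-3-yl at this place gives a 1.1-fold higher number from compound 2 to compound 4 (0.03 log units; within the scatter) and so does not separate the two groups. No supporting measurement bears on this result. Open, going by these compounds, is whether pyridin-2-yl, phenyl or an aminomethyl-bearing ring at this place would also stay within the scatter. Also open, on these data alone, is whether pyridin-4-yl behaves alike with chloro or cyano in place of bromo.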